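The source may report more compounds than this note shows. Statements on the series, on what has been measured and on what is new or still open speak of the compounds shown alone.

Among the compounds with values here, compound 2 `CC(C)(C)c1ccc(NC(=O)c2ccc(-c3ncccc3C(=O)O)cc2)cc1` gives 560 nM in a functional assay for antagonist activity at transient receptor potential cation channel subfamily V member 1 (Rattus norvegicus) (a higher number here means a weaker inhibitor, a lower number a stronger inhibitor), the higher of the two numbers measured so far; compound 1 `CC(C)(C)c1ccc(NC(=O)c2ccc(-c3ncccc3N(S(C)(=O)=O)S(C)(=O)=O)cc2)cc1` gives 0.4 nM. Within the data shown here, the only measured step is a 1400-fold higher number from compound 1 to compound 2 (3.15 log units; beyond the scatter), which shows how much the group at this position can matter. Compound 3 `CC(C)(C)c1ccc(NC(=O)c2ccc(-c3ncccc3C(=N)N)cc2)cc1` differs from compound 2 by a group of 3 heavy atoms (1 carbon, 2 nitrogen; no ring) in place of a group of 3 heavy atoms (1 carbon, 2 oxygen; no ring), on an aromatic carbon. Among the measured compounds shown here, no measured step covers this particular exchange, so its direction is open; the new group shares neither the shape nor the atoms of the group in compound 1. For compound 3 a step of about a 1.4-fold higher number from compound 2 to compound 3 (0.15 log units; within the scatter) is expected, which means an estimated 800 nM, plausibly between 100 nM and 6000 nM.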

Compound 3, half-maximal inhibitory concentration: > 4000 nM
Compound 3 ended at the assay's limit; the forecaster's own chance of this, stated with the estimate: 15%; middle value at least 5.0-fold (0.69 log units) away from the limit.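

The value of compound 3 is a limit and not a number: the limit of > 4000 nM in this assay, at which 1 of the 3 values shown sits. Even so, putting the group with 1 carbon and 2 nitrogen in place of carboxy on this aromatic carbon gives an at least 7.1-fold higher number from compound 2 to compound 3 (0.85 log units; beyond the scatter), so two groups of equal heavy-atom count are not interchangeable here. Replacing bis(methylsulfonyl)amino gives an at least 10000-fold higher number from compound 1 to compound 3 (4.00 log units; beyond the scatter), and compound 1 remains the strongest inhibitor of the three. Open, as far as these compounds go, is how an amine or a single methylsulfonylamino group would behave on this carbon. From the compounds shown here alone, the true value of compound 3 also remains unknown.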